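The compounds below may be only part of what the source reports. "The series", "measured", "known", "first", "only" and "open" are said of these compounds alone.

Compound 1 `CS(=O)(=O)N1CC(CCl)c2ccc(N)cc21` stands with the highest of the two numbers recorded: in a functional assay on CHO-AA8 cells (Cricetulus griseus) for cytotoxicity, with a stated time of 4 h (on this read-out lower numbers stand for stronger inhibition and higher numbers for weaker inhibition), compound 1 gives 158000 nM. Among the compounds with values here, its nearest neighbour, compound 2 `CNc1ccc2c(c1)N(S(C)(=O)=O)CC2CCl`, gives 50000 nM in this assay, and the step of a 3.2-fold lower number from compound 1 to compound 2 (0.50 log units; beyond the scatter) is the only measured step available. Compound 3 `CSc1ccc2c(c1)N(S(C)(=O)=O)CC2CCl` differs from compound 1 by methylsulfanyl in place of amino on an aromatic carbon. That is not the change measured between compound 1 and compound 2, so that step bears on it only as a hint that altering the amino group shifts the number modestly downward. Compound 3 is therefore expected to show a step of a 2.0-fold lower number from compound 1 to compound 3 (0.30 log units; within the scatter) in this assay, a modest lowering at most. The estimate for compound 3 is 80000 nM, with a range from 25000 nM to 250000 nM.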

Compound 3, half-maximal inhibitory concentration: > 200000 nM
Compound 3: no number, only a limit; the forecaster's own chance of this, stated with the estimate: 10%; middle value at least 2.5-fold (0.39 log units) away from the limit.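

Compound 3 gives no number in this assay, only a limit of the assay: the limit of > 200000 nM in this assay, at which 1 of the 3 values shown sits. Methylsulfanyl in place of amino on this aromatic carbon gives an at least 1.2-fold higher number from compound 1 to compound 3 (0.10 log units; that floor lies within the scatter), so this floor does not separate the two compounds. Methylsulfanyl in place of methylamino gives an at least 4.0-fold higher number from compound 2 to compound 3 (0.60 log units; beyond the scatter), which shows that the lowering seen with methylamino does not carry over to methylsulfanyl at this position. The compounds shown leave open how far compound 3 lies past its limit. They also leave open whether a methoxy or dimethylamino group on this aromatic carbon would track methylamino or methylsulfanyl.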